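A Methoxy Addition Tested on Two Related Cores

A few compounds are considered here, and "the series" means these few. Any claim that something is new, unique, unknown or untested is made for them only; others in the source may bear on it.

Compound 1 `COc1cc(OC)cc([C@@H]2/C(=C\c3ccccc3)c3cc(OC)cc(OC)c3[C@H]2c2ccccc2)c1`: in a functional assay on RAW264.7 cells (Mus musculus) for inhibition, with stated times of 2 h and 24 h (a higher number here means a weaker inhibitor, a lower number a stronger inhibitor), compound 1 gives > 200000 nM, a limit of the assay and not a number.
Compound 2 `COc1ccc(/C=C2/c3cc(OC)cc(OC)c3[C@@H](c3ccccc3)[C@@H]2c2cc(OC)cc(OC)c2)cc1`: in this assay compound 2 gives > 200000 nM, again a limit and not a number.
For the measured compounds named here, compound 3 `COc1cc(OC)cc([C@@H]2C(C(O)c3ccccc3)c3cc(OC)cc(OC)c3[C@H]2c2ccccc2)c1`: in this assay compound 3 gives 21600 nM, the only number among the three.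

Compound 1 and compound 2 differ in one place, (methoxy in place of hydrogen on an aromatic carbon). The step in this assay is a step that the two limits leave unreadable from compound 1 to compound 2, since both values sit at the limit of > 200000 nM in this assay, at which 2 of the 3 values shown sit. The difference between the core of compound 1 and the core of compound 3 is not broken down here.

Compound 4 `COc1ccc(C(O)C2c3cc(OC)cc(OC)c3[C@@H](c3ccccc3)[C@@H]2c2cc(OC)cc(OC)c2)cc1` has not yet been measured. It stands to compound 3 as compound 2 stands to compound 1: the change is methoxy in place of hydrogen on an aromatic carbon, and the two place descriptions agree word for word, so this is the same change made a second time, now on the core of compound 3.

Because the earlier step is a step that the two limits leave unreadable from compound 1 to compound 2, its size carries no information about what this change does to potency. The expectation for compound 4 therefore rests on compound 3 alone, whose value is 21600 nM, and the step from compound 3 to compound 4 is expected to be a 1.1-fold lower number from compound 3 to compound 4 (0.03 log units; within the scatter), that is, within the usual scatter. Compound 4 is thus estimated at 20000 nM, with a wide range from 5000 nM to 100000 nM to cover the uncertain direction.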

Compound 4, half-maximal inhibitory concentration: 16500 nM
For compound 4 the middle estimate is 1.2-fold (0.08 log units) above the measured one, within the range that was stated.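

In this assay, replacing hydrogen with methoxy, which turns hydroxy(phenyl)methyl into hydroxy(4-methoxyphenyl)methyl, gives a 1.3-fold lower number from compound 3 to compound 4 (0.12 log units; within the scatter), so on the core of compound 3 the two compounds cannot be told apart. For the compounds shown here, the same change on the core of compound 1 cannot be read, since compound 1 and compound 2 both sit at a limit of the assay and not at a number: the limit of > 200000 nM in this assay, at which 2 of the 4 values shown sit. Carrying the change from one core to the other therefore yields only one readable step, which shows that methoxy is tolerated on the core of compound 3 in this assay, but it does not show that the change behaves alike on both cores or that it would do so on any further core.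

The compounds shown leave open whether an amine, a carboxylic acid or a longer chain such as butoxy, set on the same aromatic carbon, would give a step beyond the scatter on the core of compound 3. They also leave open which part of the difference between the core of compound 1 and the core of compound 3 separates the two limits from the two measured numbers.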